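The source may report more compounds than this note shows. Statements on the series, on what has been measured and on what is new or still open speak of the compounds shown alone.

Working notes on the series. For the measured compounds named here, compound 1 `CC1(C)[C@H]2CC[C@]1(C)N(Cc1cn(-c3cccc(C#N)c3)nn1)C(=O)C2` gives 260 nM in a functional assay on PANC-1 cells (Homo sapiens) for inhibition, read by MTT assay, with a stated time of 24 h; on this read-out higher numbers stand for weaker inhibition and lower numbers for stronger inhibition; it is one of only two compounds measured, and its number and that of compound 2 lie within the scatter of each other. Compound 2 `Cc1ccc(-n2cc(CN3C(=O)C[C@@H]4CC[C@@]3(C)C4(C)C)nn2)cc1` gives 270 nM. Going by the values given here, the one step known, a 1.0-fold higher number from compound 1 to compound 2 (0.02 log units; within the scatter), swaps 4-methylphenyl in place of 3-cyanophenyl on an aromatic nitrogen.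

Compound 3 `Cc1cccc(-n2cc(CN3C(=O)C[C@@H]4CC[C@@]3(C)C4(C)C)nn2)c1` differs from compound 1 by methyl in place of cyano on an aromatic carbon. Among the compounds with values here, only that single step bears on it, and it was flat. The step from compound 1 to compound 3 is therefore expected to be a 1.0-fold higher number from compound 1 to compound 3 (0.02 log units; within the scatter). Compound 3 is expected to give 270 nM, with a range of 130 nM to 560 nM.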

Compound 3, half-maximal inhibitory concentration: 240 nM
Beside the measured number, compound 3's estimate is 1.1-fold (0.05 log units) above it, and the stated range covers the measured number.
By their numbers in this assay, from the lowest: compounds 3, 1 and 2 (each within the scatter of the next).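

In this assay the step of a 1.1-fold lower number from compound 1 to compound 3 (0.03 log units; within the scatter) shows that, on this aromatic carbon, methyl and cyano cannot be told apart, whereas the earlier step changed both the group and its place. The step of a 1.1-fold lower number from compound 2 to compound 3 (0.05 log units; within the scatter) adds that 3-methylphenyl and 4-methylphenyl also cannot be told apart. No measurement on hand explains these results. Still open, as far as these compounds go, is whether an amine or a carboxylic acid on this ring would give a step beyond the scatter. Also open, from the compounds shown here alone, is what a chlorine or methoxy group would do here.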